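Chloro in Place of Methoxy: From Compound 2 to Compound 4

This account rests on a few compounds, and the source may have more. Where it says the series, first, only, none or still open, it means among the compounds named here.

Three measured compounds share one core: compound 1 `CCOC(=O)/C=C/c1ccc(OC(=O)c2nc(C)c(C)nc2C)c(O)c1`, compound 2 `CCOC(=O)/C=C/c1cc(OC)ccc1OC(=O)c1nc(C)c(C)nc1C` and compound 3 `Cc1nc(C)c(C(=O)Oc2ccc(/C=C/C(=O)O)cc2)nc1C`. In a functional assay on EA.hy 926 cells (Homo sapiens) for cytotoxicity, read by MTT assay, with stated times of 24 h and 12 h, tested at 25 uM (on this read-out higher numbers stand for a stronger effect at the one concentration tested and lower numbers for a weaker effect), compound 1 gives 207%, compound 3 gives 46.6%, and compound 2 gives 23.4%, the lowest of the three numbers; its nearest neighbour, compound 3, sits higher by a gap beyond the usual scatter, and compound 1 sits far higher still. The unmeasured compound 4 `CCOC(=O)/C=C/c1cc(Cl)ccc1OC(=O)c1nc(C)c(C)nc1C` differs from compound 2 in one place: chloro in place of methoxy on an aromatic carbon. For the measured compounds named here, no measured pair differs in only this place, so the size of this step cannot be read from the data; a small step is expected, possibly none beyond the scatter, with a modest rise more likely than a fall. Compound 4 is therefore estimated at 32% in this assay, within 12% to 70%, an expected step of a number 8.6 percentage points higher from compound 2 to compound 4 (within the scatter).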

Compound 4, a percentage reported as activity, at one concentration (the size of the read-out at that concentration, not a potency): 62.5%
Compound 4: the middle estimate sits 30.5 percentage points below what was measured; low and high end bracket the measured number.
By their numbers in this assay, from the lowest: compound 2; then compound 3; then compound 4; then compound 1.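

Swapping methoxy for chloro on this aromatic carbon, para to a large group and meta to a 2-(ethoxycarbonyl)ethenyl group, gives a number 39.1 percentage points higher from compound 2 to compound 4 (beyond the scatter) in this assay and is a large step. For the compounds shown here, it is the first change in a single place that can be read, and it shows that the group at this carbon matters to the read-out. No measurement shown bears on why the number rises.

Still open, as far as these compounds go, is whether the rise is particular to chloro. A bromo group or an amine at this carbon could give a higher number, a similar one or a lower one.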